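Aryl hydrazone variation on the shared core

The source may report more compounds than this note shows. Statements on the series, on what has been measured and on what is new or still open speak of the compounds shown alone.

For the measured compounds named here, compound 1 `Cn1c(=O)c(=O)n(C2CCCC2)c2nc(N/N=C/c3ccc(F)c(Cl)c3)ncc21` is the stronger of the two compounds measured so far in a functional assay on PC-3 cells (Homo sapiens) for antiproliferative activity, read by MTT assay; a higher number here means a weaker inhibitor, a lower number a stronger inhibitor: compound 1 gives 8550 nM. Its companion is compound 2 `Cn1c(=O)c(=O)n(C2CCCC2)c2nc(N/N=C/c3cccc(O)c3)ncc21`, in which a 3-hydroxyphenyl group stands in place of the 3-chloro-4-fluorophenyl group on a carbon with a double bond to nitrogen; in this assay compound 2 gives 36300 nM. Going by the values given here, the one step recorded, a 4.2-fold higher number from compound 1 to compound 2 (0.63 log units; beyond the scatter), shows that exchanging the aryl group at this position moves the number by a modest but real amount.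

Compound 3 `Cn1c(=O)c(=O)n(C2CCCC2)c2nc(N/N=C/c3ccccc3F)ncc21` is not yet measured. It differs from compound 1 as follows: 2-fluorophenyl in place of 3-chloro-4-fluorophenyl on a carbon with a double bond to nitrogen. Among the compounds with values here, the only measured step that bears on this change is a 4.2-fold higher number from compound 1 to compound 2 (0.63 log units; beyond the scatter), which concerns the same position but a different entering group. The expectation is therefore a step of comparable or smaller size, most likely toward a higher number, although the evidence is too thin to exclude no change beyond the scatter. For compound 3 the estimated value in this assay is 15000 nM, with a range from 5000 nM to 45000 nM, which would correspond to an expected step of a 1.8-fold higher number from compound 1 to compound 3 (0.24 log units; within the scatter).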

Compound 3, half-maximal inhibitory concentration: 27600 nM
The estimate for compound 3 lay 1.8-fold (0.26 log units) below the measured number, and the stated range covers the measured number.
By their numbers in this assay, from the lowest: compound 1; then compounds 3 and 2 (each within the scatter of the next).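

In this assay, the change to the 2-fluorophenyl group gives a 3.2-fold higher number from compound 1 to compound 3 (0.51 log units; beyond the scatter), so a second entering group, this one without a hydroxyl, also fails to match the 3-chloro-4-fluorophenyl group, which holds the lowest number among the three compounds shown. The two entering groups cannot be told apart here, with a 1.3-fold lower number from compound 2 to compound 3 (0.12 log units; within the scatter), even though the 2-fluorophenyl and 3-hydroxyphenyl groups carry different substituents and differ in their counted hydrogen-bond donors and acceptors. Nothing in the available data bears on the reason for these differences.

The step to compound 3 removes the chlorine and also changes the name-given location of the fluorine, so the compounds shown do not say which of these two differences accounts for the step, and a 3-chlorophenyl or a 4-fluorophenyl group on the same carbon would separate them. It also remains open how the number responds when the aryl group at this position carries an amine or a carboxylic acid, as all three compounds shown bear only halogen or hydroxyl substituents on the phenyl ring.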